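The source may report more compounds than this note shows. Statements on the series, on what has been measured and on what is new or still open speak of the compounds shown alone.

Measured compounds: compound 1 `CC(C)(N)CC(=O)N[C@@H]1CCc2ccccc2N(Cc2ccc(-c3ccccc3C(N)=O)cc2)C1=O` with 0.08 uM; compound 2 `CC(C)(N)CC(=O)N[C@@H]1CCc2ccccc2N(Cc2ccc(-c3ccccc3S(N)(=O)=O)cc2)C1=O` with 3 uM; compound 3 `CC(C)(N)CC(=O)N[C@@H]1CCc2ccccc2N(Cc2ccc(-c3ccccc3C(=O)O)cc2)C1=O` with 3 uM, all in a functional assay (Pituitary gland cell) with Rattus norvegicus as the target; on this read-out lower numbers stand for an effect already at smaller amounts and higher numbers for an effect only at larger amounts of compound.

Among the compounds with values here, compound 3 sits level with compound 2, the two together giving the highest numbers of the three; its only step beyond the scatter is a 38-fold higher number from compound 1 to compound 3 (1.57 log units; beyond the scatter). Compound 4 `CC(O)Cn1nnnc1-c1ccccc1-c1ccc(CN2C(=O)[C@H](NC(=O)CC(C)(C)N)CCc3ccccc32)cc1` carries the change (1-(2-hydroxypropyl)-1H-tetrazol-5-yl in place of carboxy on an aromatic carbon). Within the data shown here, no measured step touches the entering group. Among the measured compounds shown here, the steps that bear on it are a 38-fold higher number from compound 1 to compound 3 (1.57 log units; beyond the scatter) and no change at the digits printed from compound 2 to compound 3 (within the scatter), showing that the group on this aromatic carbon can move the number a great deal or not at all. For the measured compounds named here, with no direct precedent, a moderate shift toward lower numbers is expected, a 6.0-fold lower number from compound 3 to compound 4 (0.78 log units; beyond the scatter), and compound 4 is estimated at 0.5 uM within 0.05 uM to 5 uM.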

Compound 4, concentration for half-maximal effect: 0.05 uM
Compound 4: the middle estimate sits 10-fold (1.00 log units) above what was measured; low and high end bracket the measured number.
By their numbers in this assay, from the lowest: compounds 4 and 1 (each within the scatter of the next); then compounds 2 and 3 (each within the scatter of the next).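

In this assay, the aromatic carbon ortho to a large group accepts 1-(2-hydroxypropyl)-1H-tetrazol-5-yl in place of carboxy with a 60-fold lower number from compound 3 to compound 4 (1.78 log units; beyond the scatter), and in place of sulfamoyl with a 60-fold lower number from compound 2 to compound 4 (1.78 log units; beyond the scatter). Within the data shown here, in place of carbamoyl the same group gives a 1.6-fold lower number from compound 1 to compound 4 (0.20 log units; within the scatter), so carbamoyl is no longer the only group here that reaches the low end of the series. No measured evidence bears on what separates these groups.

Open: whether the tetrazole ring or its 2-hydroxypropyl chain carries the step, and whether a plain propyl chain or an amine on that chain holds the number at this level.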